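The compounds below may be only part of what the source reports. "The series", "measured", "known", "first", "only" and "open" are said of these compounds alone.

Four closely related compounds share one core and differ in where a methoxy group sits and in whether the side chain ends in a carboxy group or an ethoxycarbonyl group. Compound 1 `COc1ccc(OC)c2c1c(C(=O)/C=C(\O)C(=O)O)cn2Cc1ccc(F)cc1` gives 213000 nM in an ADME assay on MT4 cells (Homo sapiens) for cytotoxicity, read by MTT assay; a higher number here means that more compound is tolerated, a lower number that less compound is tolerated. Compound 2 `CCOC(=O)/C(O)=C/C(=O)c1cn(Cc2ccc(F)cc2)c2cc(OC)ccc12` gives 100000 nM in this assay. Compound 3 `CCOC(=O)/C(O)=C/C(=O)c1cn(Cc2ccc(F)cc2)c2c(OC)cccc12` is reported in this assay only as a limit, > 100000 nM, which is the limit of > 100000 nM in this assay, at which 1 of the 3 values shown sits, so its exact number is not known. Compound 4 `COc1cccc2c(C(=O)/C=C(\O)C(=O)O)cn(Cc3ccc(F)cc3)c12` has not yet been measured in this assay; it differs from compound 3 by hydrogen in place of ethyl on an oxygen next to a carbonyl group. No step between measured compounds is shown, and the values of compound 1 213000 nM and compound 2 100000 nM lie near each other, so no change beyond the usual scatter is expected in this assay. Compound 4 is therefore expected to give about 200000 nM, between 80000 nM and 500000 nM, an expected step that the limit leaves unreadable from compound 3 to compound 4.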

Compound 4, half-maximal cytotoxic concentration: 82900 nM
Beside the measured number, compound 4's estimate is 2.4-fold (0.38 log units) above it, and the stated range covers the measured number.
By their numbers in this assay, from the lowest: compounds 4 and 2 (each within the scatter of the next); then compound 1.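

Hydrogen in place of methoxy on an aromatic carbon gives a 2.6-fold lower number from compound 1 to compound 4 (0.41 log units; beyond the scatter), the first step in this series shown beyond the scatter, with less compound tolerated. Hydrogen in place of ethyl on an oxygen next to a carbonyl group gives an at least 1.2-fold lower number from compound 3 to compound 4 (0.08 log units; that floor lies within the scatter). That step is only a floor because compound 3 stands at a limit: the limit of > 100000 nM in this assay, at which 1 of the 4 values shown sits.

As far as these compounds go, how a longer chain in place of the ethyl would read remains open. So does whether an amine or a chlorine in place of the methoxy would follow the same course as hydrogen.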